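This account rests on a few compounds, and the source may have more. Where it says the series, first, only, none or still open, it means among the compounds named here.

In a functional assay on SMMC-7721 cells (Homo sapiens) for cytotoxicity, read by MTT assay, with a stated time of 24 h (on this read-out higher numbers stand for weaker inhibition and lower numbers for stronger inhibition), compound 1 `N#Cc1ccc(/C=C2\CN(S(=O)(=O)c3ccc(F)cc3)C/C(=C\c3ccccc3F)C2=O)cc1` gives 10300 nM, compound 2 `COc1cc(/C=C2\CN(S(=O)(=O)c3ccc(F)cc3)C/C(=C\c3ccccc3F)C2=O)cc(OC)c1` gives 6890 nM and compound 3 `COc1cc(/C=C2\CN(S(=O)(=O)c3ccc(F)cc3)C/C(=C\c3cc(OC)c(OC)c(OC)c3)C2=O)cc(OC)c1` gives 5420 nM. Compound 2 holds the middle place among these three numbers, but its steps to both others lie within the scatter: a 1.5-fold lower number from compound 1 to compound 2 (0.17 log units; within the scatter) and a 1.3-fold lower number from compound 2 to compound 3 (0.10 log units; within the scatter).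

Compound 4 `COc1cc(/C=C2\CN(S(=O)(=O)c3ccc(NC(C)=O)cc3)C/C(=C\c3ccccc3F)C2=O)cc(OC)c1` has not yet been measured. Its difference from compound 2 is acetamido in place of fluoro on an aromatic carbon. In words, this is acetamido in place of fluoro on an aromatic carbon, para to a large group, or 4-fluorophenyl to 4-acetamidophenyl when cut one bond further out.

Neither measured step bears directly on this change. Going by the values given here, both exchange a group on a double-bonded chain carbon, and no measured pair varies the 4-fluorophenyl group. Among the compounds with values here, they show only that those two exchanges stayed within the scatter, so they offer indirect guidance at best.

No step beyond the scatter is therefore expected in this assay, and the data give no basis for a direction. The expected change is a 1.1-fold lower number from compound 2 to compound 4 (0.03 log units; within the scatter). Going by these compounds, the estimate stays anchored on compound 2 at 6890 nM, with a wide range since this position is untested. Compound 4 is expected at 6500 nM, within an estimated range of 2800 nM to 14000 nM.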

Compound 4, half-maximal inhibitory concentration: 5210 nM
The estimate for compound 4 lay 1.2-fold (0.10 log units) above the measured number; measured number inside the range.
By their numbers in this assay, from the lowest: compounds 4, 3, 2 and 1 (each within the scatter of the next).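

In this assay, going by these compounds alone, the exchange of fluoro for acetamido on an aromatic carbon, para to a large group, gives a 1.3-fold lower number from compound 2 to compound 4 (0.12 log units; within the scatter) and is the first reading at this position, as the earlier steps changed only groups on a double-bonded chain carbon. In this one pair, 4 heavy atoms with 1 hydrogen-bond donor and 1 hydrogen-bond acceptor replace a single fluorine without a step beyond the scatter, so the 4-fluorophenyl group is not shown to be required for the cytotoxicity read here. No measurement among the data explains why the number stays within the scatter after this change.

The compounds shown leave open whether an amine or a carboxylic acid at this place, or an amide with a longer chain than acetamido, would also stay within the scatter. They also leave open whether the 4-acetamidophenyl group would behave the same way alongside the 3,4,5-trimethoxyphenyl group of compound 3 in place of the 2-fluorophenyl group of compound 4.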